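This account rests on a few compounds, and the source may have more. Where it says the series, first, only, none or still open, it means among the compounds named here.

Measured:
compound 1 `O=C(O)CCCCCC(=O)N1CCC2(CC1)CCN(c1ccncc1)CC2` — 4550 nM
compound 2 `O=C(O)COC1CCN(C(=O)N2CCC3(CC2)CCN(c2ccncc2)CC3)CC1` — 2650 nM

In a functional assay for inhibition, with Homo sapiens as the target (on this read-out lower numbers stand for stronger inhibition and higher numbers for weaker inhibition), compound 1 gives 4550 nM and compound 2 gives 2650 nM; the two numbers lie within the scatter of each other, so compound 1 stands apart from nothing measured. Compound 3 `O=C(O)CCCCC(=O)N1CCC2(CC1)CCN(c1ccncc1)CC2` is not yet measured. It differs from compound 1 by carboxy in place of carboxymethyl on a saturated chain carbon, four bonds along the chain from a carbonyl carbon. Within the data shown here, no step between measured compounds bears on this change. For compound 3 the step of a 1.1-fold higher number from compound 1 to compound 3 (0.04 log units; within the scatter) is expected to stay within the scatter, in no set direction. The estimate for compound 3 in this assay is 5000 nM with a range of 2000 nM to 12000 nM.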

Compound 3, half-maximal inhibitory concentration: 4540 nM
The estimate for compound 3 lay 1.1-fold (0.04 log units) above the measured number; low and high end bracket the measured number.
By their numbers in this assay, from the lowest: compounds 2, 3 and 1 (each within the scatter of the next).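

In this assay, the change from 4-carboxybutyl to 3-carboxypropyl on the core of compound 1 gives a 1.0-fold lower number from compound 1 to compound 3 (0.00 log units; within the scatter). Among these compounds, this position therefore accepts removal of one chain carbon with no change beyond the scatter, a point the earlier compounds could not show, as they offered no single-place step. Nothing on hand explains this flat step.

Still open, going by these compounds, is whether a shorter chain such as 2-carboxyethyl would move the number beyond the scatter. The same holds for a primary amide or an amine in place of the carboxylic acid.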